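Swapping the benzyl group of compound 1 for 4-fluorobenzyl

A few compounds are considered here, and "the series" means these few. Any claim that something is new, unique, unknown or untested is made for them only; others in the source may bear on it.

In a functional assay on HCT-116 cells (Homo sapiens) for antiproliferative activity, read by MTT assay, with a stated time of 48 h (a higher number here means a weaker inhibitor, a lower number a stronger inhibitor), compound 1 (`COc1ccc(CN(C(=O)CSc2nc3ccccc3s2)c2cc(OC)c(OC)c(OC)c2)cc1O`) gives 182 nM as the lowest of three numbers. Compound 3 (`COc1ccc(CN(C(=O)CSc2nc3c(C)cccc3s2)c2cc(OC)c(OC)c(OC)c2)cc1O`) gives 852 nM and compound 2 (`COc1cc(CN(C(=O)CSc2nc3ccccc3s2)c2cc(OC)c(OC)c(OC)c2)cc(OC)c1OC`) gives 65300 nM on the same measure.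

Compound 4 (`COc1cc(N(Cc2ccc(F)cc2)C(=O)CSc2nc3ccccc3s2)cc(OC)c1OC`) is not yet measured. It carries 4-fluorophenyl in place of 3-hydroxy-4-methoxyphenyl on a saturated chain carbon bound to an amide-type nitrogen.

The most relevant precedent is compound 2, which changes the same place and also loses the 3-hydroxy-4-methoxyphenyl. Within the data shown here, that large step runs a 360-fold higher number from compound 1 to compound 2 (2.55 log units; beyond the scatter) and is the only evidence at this place. The modest step of a 4.7-fold higher number from compound 1 to compound 3 (0.67 log units; beyond the scatter) is a methyl in place of hydrogen on an aromatic carbon, so it is a different change and bears little on this one. Among the measured compounds shown here, no fluorinated compound has been measured yet.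

For the measured compounds named here, a clear move to a higher number is therefore expected, though smaller than the one seen for compound 2. The expected step runs a 33-fold higher number from compound 1 to compound 4 (1.52 log units; beyond the scatter) in this estimate. For compound 4 the estimated value is 6000 nM with an expected range from 800 nM to 45000 nM as the outcome.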

Compound 4, half-maximal inhibitory concentration: 59800 nM
Compound 4: the middle estimate sits 10-fold (1.00 log units) below what was measured; measured number above the stated range.
By their numbers in this assay, from the lowest: compound 1; then compound 3; then compounds 4 and 2 (each within the scatter of the next).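

At this place in this assay, a second replacement of 3-hydroxy-4-methoxyphenyl gives another large step, a 330-fold higher number from compound 1 to compound 4 (2.52 log units; beyond the scatter). The replacements are different groups, 3,4,5-trimethoxyphenyl and 4-fluorophenyl, yet the step between them is a 1.1-fold lower number from compound 2 to compound 4 (0.04 log units; within the scatter), so the two entering groups cannot be told apart on this read-out. Of the three groups seen at this place, only 3-hydroxy-4-methoxyphenyl goes with a low number, and no compound shown goes against that. Nothing available explains the large rise in the number.

The compounds shown exchange the whole group at once, leaving open whether the hydroxy or the methoxy of 3-hydroxy-4-methoxyphenyl matters more. Also open, as far as these compounds go, is how an amine or a carboxylic acid in place of that hydroxy would read.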